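Replacing a Chlorophenyl Ring with a Methylthiophene

The source may hold more compounds than are shown below. What is called first, only, known or untested is meant among the compounds shown, and "the series" means these compounds.

Of the compounds shown here, two with a shared core have been tested in a functional assay on HepG2 cells (Homo sapiens) for cytotoxicity, read by MTT assay, with a stated time of 48 h; a lower number here means a stronger inhibitor, a higher number a weaker inhibitor. Compound 1 (`O=C1/C(=C\c2cccc(O)c2)S/C(=N/c2ccccc2)N1Cc1ccncc1`) gives 17600 nM, and compound 2 (`O=C1/C(=C\c2cccc(Cl)c2)S/C(=N/c2ccccc2)N1Cc1ccncc1`) gives 28900 nM. These values lie within the usual scatter of each other, so compound 2 cannot be ranked against compound 1.

Compound 3 (`Cc1ccc(/C=C2/S/C(=N/c3ccccc3)N(Cc3ccncc3)C2=O)s1`) has not yet been measured. It differs from compound 2 in one place: 5-methylthiophen-2-yl in place of 3-chlorophenyl on a double-bonded chain carbon bound to a double-bonded ring carbon. In words, this is 5-methylthiophen-2-yl in place of 3-chlorophenyl on a double-bonded chain carbon bound to a double-bonded ring carbon.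

Within the data shown here, only one measured step offers any guidance: a 1.6-fold higher number from compound 1 to compound 2 (0.22 log units; within the scatter), with chloro in place of hydroxy on an aromatic carbon. That step altered a substituent on the ring, whereas this change replaces the ring itself, so it is only a loose guide. Among the measured compounds shown here, no measured compound carries a 5-methylthiophen-2-yl group. With so little evidence, no step beyond the scatter is expected in this assay, and the expected step is a 1.2-fold lower number from compound 2 to compound 3 (0.08 log units; within the scatter). For compound 3, the estimated value is 24000 nM, with an expected range from 10000 nM to 55000 nM.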

Compound 3, half-maximal inhibitory concentration: 23100 nM
Compound 3: the middle estimate sits 1.0-fold (0.02 log units) above what was measured; measured number inside the range.
By their numbers in this assay, from the lowest: compounds 1, 3 and 2 (each within the scatter of the next).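

In this assay, replacing the whole ring on the double-bonded chain carbon bound to a double-bonded ring carbon gives no readable shift (a 1.3-fold lower number from compound 2 to compound 3 (0.10 log units; within the scatter)), and the comparison with the hydroxy-bearing compound reads the same way (a 1.3-fold higher number from compound 1 to compound 3 (0.12 log units; within the scatter)). The earlier pair differed only in a substituent on a six-membered aromatic ring of carbon only, whereas compound 3 has a five-membered aromatic ring with 1 hetero atom here, so among these three compounds, 3-chlorophenyl, 3-hydroxyphenyl and 5-methylthiophen-2-yl cannot be told apart in this assay. No measurement shown bears on this result.

On these data alone, all three groups are aromatic rings without a charge, so it remains open whether a non-aromatic group such as cyclohexyl, or a ring carrying an amine or a carboxylic acid, would move the number beyond the scatter. As far as these compounds go, it is also open whether changes elsewhere on the shared core would have a larger effect in this assay than those seen at this position.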